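A few compounds are considered here, and "the series" means these few. Any claim that something is new, unique, unknown or untested is made for them only; others in the source may bear on it.

Values in a functional assay on Bel-7402 cells (Homo sapiens) for cytotoxicity, read by MTT assay, with a stated time of 72 h; on this read-out higher numbers stand for weaker inhibition and lower numbers for stronger inhibition:
- compound 1 `C=C1C(=O)[C@@]23C(=O)OC[C@]4([C@@H](OC(C)=O)CCC(C)(C)[C@H]4C=O)[C@@H]2CC[C@@H]1[C@H]3O`: 75400 nM
- compound 2 `C=C1C(=O)[C@@]23C(=O)OC[C@]4(C(=O)CCC(C)(C)[C@H]4C=O)[C@@H]2CC[C@@H]1[C@H]3OC(C)=O`: 1730 nM
- compound 3 `C=C1C(=O)[C@@]23C(=O)OC[C@]4(C(=O)CCC(C)(C)[C@H]4C=O)[C@@H]2CC[C@@H]1[C@H]3OC(=O)c1ccc(C)cc1`: 1540 nM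

Compound 3, at 1540 nM, sits within the scatter of compound 2, while compound 1 reads much higher. Compound 4 `C=C1C(=O)[C@@]23C(=O)OC[C@]4(C(=O)CCC(C)(C)[C@H]4C=O)[C@@H]2CC[C@@H]1[C@H]3OC(=O)c1ccc(F)cc1` differs from compound 3 by fluoro in place of methyl on an aromatic carbon, with fluoro in place of methyl on an aromatic carbon, para to a large group. Going by the values given here, only one measured step bears on this part of the molecule: 4-methylphenyl in place of methyl on a carbonyl carbon, a 1.1-fold lower number from compound 2 to compound 3 (0.05 log units; within the scatter). Among the compounds with values here, no measured step covers the fluoro change itself, so no shift beyond the scatter is expected in this assay. The expected change is a 1.0-fold lower number from compound 3 to compound 4 (0.01 log units; within the scatter). Compound 4 is estimated at 1500 nM, with an expected range of 700 nM to 3200 nM.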

Compound 4, half-maximal inhibitory concentration: 3750 nM
Compound 4: middle estimate off by 2.5-fold (0.40 log units), on the low side; measured number above the stated range.
By their numbers in this assay, from the lowest: compounds 3 and 2 (each within the scatter of the next); then compound 4; then compound 1.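

The ring substituent on this ester matters in this assay, which the earlier swap of methyl for 4-methylphenyl did not reveal: fluoro in place of methyl gives a 2.4-fold higher number from compound 3 to compound 4 (0.39 log units; beyond the scatter). The 4-fluorophenyl group also separates from methyl on the carbonyl carbon, with a 2.2-fold higher number from compound 2 to compound 4 (0.34 log units; beyond the scatter), whereas 4-methylphenyl stayed within the scatter of methyl. Nothing available explains this shift. Going by these compounds, it remains open whether chloro, methoxy or an amine at this ring carbon would read nearer compound 3 or compound 4. Also open, on these data alone, is how a longer alkyl chain on the carbonyl carbon would compare with methyl.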